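The source may report more compounds than this note shows. Statements on the series, on what has been measured and on what is new or still open speak of the compounds shown alone.

Measured compounds:
- compound 1, `O=[N+]([O-])c1cn2c(n1)OC[C@@H](OCCOc1ccc(-c3ccc(OC(F)(F)F)cc3)cc1)C2`: 0.68 ug/mL
- compound 2, `O=[N+]([O-])c1cn2c(n1)OC[C@@H](OCCOc1ccc(OCc3ccccc3)cc1)C2`: 1.7 ug/mL
- compound 3, `O=[N+]([O-])c1cn2c(n1)OC[C@@H](OC/C=C/c1ccc(-c3ccc(OC(F)(F)F)cc3)cc1)C2`: 0.5 ug/mL

All three were read in a physicochemical assay for solubility, read by HPLC, at pH 7; on this read-out higher numbers stand for higher solubility and lower numbers for lower solubility. Compound 1 and compound 2 share a core and differ in one place: benzyloxy in place of 4-(trifluoromethoxy)phenyl on an aromatic carbon. That change gave a 2.5-fold higher number from compound 1 to compound 2 (0.40 log units; beyond the scatter). Among the compounds with values here, compound 3 carries a different core, and the difference between the two cores is not broken down here; in this assay compound 3 gives 0.5 ug/mL, a number within the scatter of the one for compound 1, so the two cannot be told apart on this read-out.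

Compound 4, `O=[N+]([O-])c1cn2c(n1)OC[C@@H](OC/C=C/c1ccc(OCc3ccccc3)cc1)C2`, has not yet been measured. It stands to compound 3 exactly as compound 2 stands to compound 1: benzyloxy in place of 4-(trifluoromethoxy)phenyl on an aromatic carbon. The place of the change is described in the same words for both pairs, so the change is the same one, made on a second core.

Within the data shown here, because a 2.5-fold higher number from compound 1 to compound 2 (0.40 log units; beyond the scatter) is the only example of this change, a step of about that size is expected again, estimated as a 2.4-fold higher number from compound 3 to compound 4 (0.38 log units; beyond the scatter). This rests on a single pair, so the expectation is loose rather than firm. In this assay compound 4 is estimated at 1.2 ug/mL. For compound 4 the expected range runs from 0.6 ug/mL to 2.5 ug/mL.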

Compound 4, solubility: 0.06 ug/mL
For compound 4 the middle estimate is 20-fold (1.30 log units) above the measured one, and the stated range ends above it.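

In this assay the same change, benzyloxy in place of 4-(trifluoromethoxy)phenyl on an aromatic carbon, gave a 2.5-fold higher number from compound 1 to compound 2 (0.40 log units; beyond the scatter) and then an 8.3-fold lower number from compound 3 to compound 4 (0.92 log units; beyond the scatter); both steps lie beyond the scatter, and they run in opposite directions. This shows that, across these two pairs, the change did not carry from one core to the other, so the step seen on the first core was no reliable guide to the step on the second, but each direction rests on a single pair and no general rule for either core follows from it. The data shown offer no measurement that explains why the same change behaves differently on the two cores.

The compounds shown cover only two cores and only these two groups at this place, so it remains open which direction the change would take on a third core. From the compounds shown here alone, it also remains open how each core would respond to a different group on the same aromatic carbon, such as an amine or a carboxylic acid, or to a longer chain joining the core to the aromatic ring.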